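Swapping the aryl ether ring on a quinazolinone hydrazone

The source may hold more compounds than are shown below. What is called first, only, known or untested is meant among the compounds shown, and "the series" means these compounds.

In a physicochemical assay for lipophilicity, in phosphate buffer, measured as octanol-water partition (a higher number here means a more lipophilic compound, a lower number a more polar compound), compound 1 `Cc1nc2ccccc2c(=O)n1/N=C/c1ccc(Oc2ccc3ccccc3c2)cc1` gives 5.22 and compound 2 `O=c1c2ccccc2nc(-c2ccccc2)n1/N=C/c1ccc(Oc2ccc3ccccc3c2)cc1` gives 6.53, the higher of the two numbers, after the step of a number 1.31 log units higher from compound 1 to compound 2 (beyond the scatter). Compound 3 `O=c1c2ccccc2nc(-c2ccccc2)n1/N=C/c1ccc(Oc2ccc(Cl)cc2)cc1` differs from compound 2 by 4-chlorophenyl in place of naphthalen-2-yl on an oxygen on an aromatic ring. Among the compounds with values here, no measured step touches this position, so the one known step is only a rough guide to how much one ring change can move this assay. A modest fall beyond the scatter is expected, a number 0.53 log units lower from compound 2 to compound 3 (beyond the scatter), putting compound 3 at an estimated 6, within 5.5 to 6.5.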

Compound 3, partition coefficient: 6.38
Compound 3: the middle estimate sits 0.38 log units below what was measured; the measured number falls inside the stated range.
By their numbers in this assay, from the lowest: compound 1; then compounds 3 and 2 (each within the scatter of the next).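

In this assay, 4-chlorophenyl in place of naphthalen-2-yl on an oxygen on an aromatic ring gives a number 0.15 log units lower from compound 2 to compound 3 (within the scatter), so this position tolerates the exchange without a readable shift. That holds even though one of the two carbon rings leaves and a chlorine enters. No measurement here offers an explanation for this result.

From the compounds shown here alone, what an amine or a carboxylic acid on this ring would do remains open. So does whether the same exchange would read alike with the methyl of compound 1 on the core.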